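Swapping the amide cap: bicyclic aryl to cinnamoyl

The source may hold more compounds than are shown below. What is called first, only, known or untested is meant among the compounds shown, and "the series" means these compounds.

Measured compounds:
- compound 1, `CCc1ccc(C(=O)NC[C@H]2c3[nH]c4ccccc4c3C[C@H]3[C@H]4c5[nH]c6ccccc6c5C[C@@H]([C@H](C#N)N23)N4C)cc1`, 100 nM in a functional assay on HCT-116 cells (Homo sapiens) for cytotoxicity, read by MTT assay, with a stated time of 72 h; on this read-out lower numbers stand for stronger inhibition and higher numbers for weaker inhibition
- compound 2, `CN1[C@@H]2c3[nH]c4ccccc4c3C[C@H]1[C@H](C#N)N1[C@@H](CNC(=O)c3ccc4ccccc4c3)c3[nH]c4ccccc4c3C[C@@H]21`, 420 nM in this assay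
- compound 3, `CN1[C@@H]2c3[nH]c4ccccc4c3C[C@H]1[C@H](C#N)N1[C@@H](CNC(=O)c3cc4ccccc4s3)c3[nH]c4ccccc4c3C[C@@H]21`, 500 nM in this assay

These three share one core and differ only in the group attached to the carbonyl carbon of the amide. Compound 3 gives the largest number of the three, though its gap to compound 2 is small: a 1.2-fold higher number from compound 2 to compound 3 (0.08 log units; within the scatter). Against compound 1, both bicyclic caps give larger numbers: a 4.2-fold higher number from compound 1 to compound 2 (0.62 log units; beyond the scatter) and a 5.0-fold higher number from compound 1 to compound 3 (0.70 log units; beyond the scatter).

Compound 4, `COc1ccc(/C=C/C(=O)NC[C@H]2c3[nH]c4ccccc4c3C[C@H]3[C@H]4c5[nH]c6ccccc6c5C[C@@H]([C@H](C#N)N23)N4C)cc1`, is the next step: 2-(4-methoxyphenyl)ethenyl in place of 1-benzothiophen-2-yl on a carbonyl carbon. Among the compounds with values here, no measured step covers this exact change. Within the data shown here, the two steps that bear on it show that the single six-membered ring of compound 1 gave a lower number than either bicyclic cap, and the entering group likewise carries a single six-membered ring, now held away from the carbonyl by a double bond. On that basis a modest drop in number is expected, a 2.0-fold lower number from compound 3 to compound 4 (0.30 log units; within the scatter), without reaching compound 1. Compound 4 is estimated at 250 nM, with a range from 80 nM to 800 nM.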

Compound 4, half-maximal inhibitory concentration: 5060 nM
Compound 4: middle estimate off by 20-fold (1.31 log units), on the low side; measured number outside the range, above it.
By their numbers in this assay, from the lowest: compound 1; then compounds 2 and 3 (each within the scatter of the next); then compound 4.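

In this assay the 2-(4-methoxyphenyl)ethenyl cap stands well apart from all three earlier caps, with a 10-fold higher number from compound 3 to compound 4 (1.01 log units; beyond the scatter) and a 12-fold higher number from compound 2 to compound 4 (1.08 log units; beyond the scatter) and a 51-fold higher number from compound 1 to compound 4 (1.70 log units; beyond the scatter) as its steps. A single six-membered aromatic ring on this carbonyl carbon therefore does not by itself keep the number low, since compound 1 and compound 4 both carry one yet lie furthest apart of the four. Nothing available here explains this large rise.

Compound 1 and compound 4 differ both in the double bond and in the group on the ring, so the compounds shown leave open which of the two matters. An unsubstituted 2-phenylethenyl cap or a plain 4-methoxyphenyl cap on the same carbonyl carbon would separate these two changes.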